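This account rests on a few compounds, and the source may have more. Where it says the series, first, only, none or still open, it means among the compounds named here.

Compound 2 `Cn1ccc2c(Oc3ccc(NC(=O)c4nn(-c5ccccc5)ccc4=O)cc3)ccnc21` gives 45200 nM in a functional assay on MCF7 cells (Homo sapiens) for cytotoxicity, read by MTT assay, with a stated time of 72 h (on this read-out higher numbers stand for weaker inhibition and lower numbers for stronger inhibition), the only number obtained among the compounds shown. Compound 1 `COc1ccc(-n2ccc(=O)c(C(=O)Nc3ccc(Oc4ccnc5c4ccn5C)cc3)n2)cc1` reaches only the assay limit, > 60000 nM, in this assay. Within the data shown here, the one measured step, an at least 1.3-fold lower number from compound 1 to compound 2 (0.12 log units; that floor lies within the scatter), is the sole guide to how a change on this ring plays out, and it stayed within the scatter. Compound 3 `Cn1ccc2c(Oc3ccc(NC(=O)c4nn(-c5ccc(Br)cc5F)ccc4=O)cc3)ccnc21` carries 4-bromo-2-fluorophenyl in place of phenyl on an aromatic nitrogen. Among the measured compounds shown here, as the only prior change on this ring moved the number by no more than the scatter, no larger shift is expected here. Compound 3 is therefore estimated at 30000 nM, between 8000 nM and 80000 nM, a step of a 1.5-fold lower number from compound 2 to compound 3 (0.18 log units; within the scatter).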

Compound 3, half-maximal inhibitory concentration: 19800 nM
For compound 3 the middle estimate is 1.5-fold (0.18 log units) above the measured one; measured number inside the range.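

In this assay the change to 4-bromo-2-fluorophenyl gives a 2.3-fold lower number from compound 2 to compound 3 (0.36 log units; beyond the scatter) and so, unlike the swap of methoxy for hydrogen, moves the number beyond the scatter. Set against 4-methoxyphenyl, the same group gives an at least 3.0-fold lower number from compound 1 to compound 3 (0.48 log units; beyond the scatter) and this step is only a floor. Compound 1 stands at a limit of the assay, which leaves that step without an upper bound: the limit of > 60000 nM in this assay, at which 1 of the 3 values shown sits. The compounds shown leave open whether the bromine or the fluorine carries the step, and how an amine or a carboxylic acid on this phenyl ring would read.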